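The source may hold more compounds than are shown below. What is called first, only, known or untested is meant among the compounds shown, and "the series" means these compounds.

Measured compounds:
Compound 1, `COc1cc2c(cc1OC)C(CC(=O)N(C)C)CC2`: in a functional assay on the whole organism (strain Wistar) for inhibition, with Rattus norvegicus as the target, read by paw edema, with stated times of 60 min and 4 h, at a dose of 100 mg/kg by the oral route (a higher number here means more inhibition at the dose given (going by the name of the read-out), a lower number less inhibition), compound 1 gives 35.9%.
Compound 2, `CCN(CC)C(=O)CC1CCc2cc(OC)c(OC)cc21`: in this assay compound 2 gives 37.5%.
Compound 3, `COc1cc2c(cc1OC)C(CC(=O)N1CCCC1)CC2`: in this assay compound 3 gives 24.2%.

All three share one core and differ only in the amine joined to the carbonyl carbon. Compound 2 has the highest of the three numbers, but its gap to compound 1 is small: a number 1.6 percentage points higher from compound 1 to compound 2 (within the scatter), so the two cannot be told apart. Compound 3 stands clearly lower: a number 13.3 percentage points lower from compound 2 to compound 3 (beyond the scatter), and likewise a number 11.7 percentage points lower from compound 1 to compound 3 (beyond the scatter).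

Compound 4, `COc1cc2c(cc1OC)C(CC(=O)N1CCOCC1)CC2`, has not yet been tested. It differs from compound 2 thus: morpholin-4-yl in place of diethylamino on a carbonyl carbon. Going by the values given here, the one earlier step that placed a ring on the carbonyl carbon, pyrrolidin-1-yl in place of an open-chain amine, brought a modest fall, while swapping one open chain for another changed little. On that basis a modest fall beyond the scatter is expected in this assay. The step from compound 2 to compound 4 is expected to be a number 10.5 percentage points lower from compound 2 to compound 4 (beyond the scatter). Compound 4 is therefore estimated at 27%, with a range from 15% to 40%.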

Compound 4, a percentage reported as inhibition, in the whole organism at one dose (the size of the read-out at that dose, not a potency): 13.3%
For compound 4 the middle estimate is 13.7 percentage points above the measured one, outside the stated range (below it).
By their numbers in this assay, from the lowest: compound 4; then compound 3; then compounds 1 and 2 (each within the scatter of the next).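

In this assay, the morpholin-4-yl group on the carbonyl carbon gives a large fall from either open-chain amine, with a number 24.2 percentage points lower from compound 2 to compound 4 (beyond the scatter) and a number 22.6 percentage points lower from compound 1 to compound 4 (beyond the scatter). The new information is that a ring at this position is not a single kind of change: one ring differs from another, with a number 10.9 percentage points lower from compound 3 to compound 4 (beyond the scatter), so compound 4 has the lowest number of the four. No measured evidence here accounts for this fall.

Morpholin-4-yl differs from pyrrolidin-1-yl in both ring size and its ring oxygen, so the compounds shown leave open which of the two goes with the lower number. A piperidin-1-yl group, which has a six-membered ring without that oxygen, would separate these two differences.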